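Swapping a Phenyl for a Methyl on a Weak Series

The source may hold more compounds than are shown below. What is called first, only, known or untested is meant among the compounds shown, and "the series" means these compounds.

Of the compounds shown here, three built around a shared core have been tested in a functional assay on MCF7 cells (Homo sapiens) for cytotoxicity, read by MTT assay, with a stated time of 48 h; on this read-out higher numbers stand for weaker inhibition and lower numbers for stronger inhibition. Compound 1 `COc1cc(COCc2cn(Cc3cc(-c4ccc(F)cc4)cnc3Cl)nn2)cc(OC)c1OC` gives 96600 nM. Compound 2 `COc1cc(-c2cc(COCc3cn(Cc4cc(-c5ccccc5)cnc4Cl)nn3)on2)cc(OC)c1OC` gives 68500 nM in this assay. Compound 3 `COc1cc(C2CC(COCc3cn(Cc4cc(-c5ccc(F)cc5)cnc4Cl)nn3)ON2C=O)cc(OC)c1OC` gives 45700 nM in this assay. Going by the values given here, the number for compound 2 lies between those of compound 1 and compound 3, and all three numbers fall within the usual scatter of one another, so no compound can be called stronger or weaker than another on these data alone.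

Compound 4 `COc1cc(-c2cc(COCc3cn(Cc4cc(C)cnc4Cl)nn3)on2)cc(OC)c1OC` has not yet been measured in this assay. It differs from compound 2 in one place: methyl in place of phenyl on an aromatic carbon. Among the compounds with values here, no pair of measured compounds shows this particular change, so its effect is unknown here. Since the three measured compounds all sit close together despite differing in several places, a small step is expected, with no clear direction beyond the scatter. Compound 4 is therefore estimated at 80000 nM, with a range from 30000 nM to 200000 nM, which means an expected step of a 1.2-fold higher number from compound 2 to compound 4 (0.07 log units; within the scatter).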

Compound 4, half-maximal inhibitory concentration: 194000 nM
For compound 4 the middle estimate is 2.4-fold (0.38 log units) below the measured one; the range from low to high includes it.
By their numbers in this assay, from the lowest: compounds 3, 2, 1 and 4 (each within the scatter of the next, the first and the last beyond it).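

In this assay, the change from phenyl to methyl on the six-membered aromatic ring with 1 nitrogen gives a 2.8-fold higher number from compound 2 to compound 4 (0.45 log units; beyond the scatter) and so weakens inhibition. Going by these compounds alone, this is the first comparison here between two compounds that differ in one place, and it shows that this position is not indifferent to what it carries, at least for this one swap on the core of compound 2. The data hold no separate measurement that would explain the step.

A single pair cannot show whether the ring itself matters or whether any group larger than methyl would serve as well. The compounds shown leave open what an ethyl group, a longer chain or an amine at this position would do, and whether any of them would move the numbers in either direction.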